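Acetyl in place of the amide hydrogen of compound 1

The source may hold more compounds than are shown below. What is called first, only, known or untested is meant among the compounds shown, and "the series" means these compounds.

Measured in a functional assay on MDA-MB-468 cells (Homo sapiens) for antiproliferative activity; on this read-out lower numbers stand for stronger inhibition and higher numbers for weaker inhibition:
Compound 1 `CC(=O)Nc1ccc(-c2nc3ccccc3s2)cc1Cl`: > 100 nM
Compound 2 `CC(=O)Nc1ccc(-c2nc3ccccc3s2)cc1Br`: > 100 nM
Compound 3 `CC(=O)Nc1ccc(-c2nc3ccccc3s2)cc1I`: > 100 nM

In this assay compound 1 gives > 100 nM, which is a limit and not a number. Compound 2 and compound 3 are also known only as limits, and the whole series sits at the limit of > 100 nM in this assay, at which 3 of the 3 values shown sit. Compound 1 therefore has no exact place on the scale.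

Compound 4 `CC(=O)N(C(C)=O)c1ccc(-c2nc3ccccc3s2)cc1Cl` keeps the core of compound 1 but has acetyl in place of hydrogen on an amide-type nitrogen, which turns acetamido to diacetylamino: acetyl in place of hydrogen on an amide-type nitrogen.

Going by the values given here, none of the measured steps touches that nitrogen. They only exchange chloro, bromo and iodo on an aromatic carbon: a step that the two limits leave unreadable from compound 1 to compound 2, a step that the two limits leave unreadable from compound 1 to compound 3 and a step that the two limits leave unreadable from compound 2 to compound 3. Their sizes cannot be read, so they give no guide to the size of this change. Among the compounds with values here, the only anchor is compound 1 at > 100 nM, again a limit, so no large step in either direction is expected. The estimated change is a step that the limit leaves unreadable from compound 1 to compound 4. For compound 4 the estimate is 200 nM, with an expected range from 40 nM to 1000 nM.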

Compound 4, half-maximal inhibitory concentration: > 1000 nM
Compound 4 gave a limit, no number (the forecaster's own chance of this, stated with the estimate: 70%); middle value at least 5.0-fold (0.69 log units) from the limit.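

In this assay compound 4 gives > 1000 nM, which is a limit and not a number. Compound 1 gives > 100 nM, also a limit. The step between compound 1 and compound 4 therefore cannot be read. The compounds shown leave open how strongly each one inhibits, and whether acetyl in place of the amide hydrogen changes that at all.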